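Cytotoxicity notes on the series: step to compound 4

This account rests on a few compounds, and the source may have more. Where it says the series, first, only, none or still open, it means among the compounds named here.

Compound 1 `O=C(Nc1cccc([N+](=O)[O-])c1)C1CCCN(C(=O)c2cc(C(F)(F)F)cc(C(F)(F)F)c2)C1` gives 9% in an ADME assay on PC-3 cells (Homo sapiens) for cytotoxicity, read by WST assay, tested at 100 uM; a higher number here means more inhibition at the concentration tested (going by the name of the read-out), a lower number less inhibition. Compound 3 `O=C(c1ccccc1)c1cccc(NC(=O)C2CCCN(C(=O)c3cc(C(F)(F)F)cc(C(F)(F)F)c3)C2)c1` gives 0% in this assay, and the step of a number 9 percentage points lower from compound 1 to compound 3 (within the scatter) stays within the scatter. Compound 2 `Cc1nc(-c2cccc(C(=O)N3CCCC(C(=O)Nc4ccc(Cl)cc4)C3)c2)no1` gives 0% in this assay, level with compound 3 at the digits shown; together they are the lowest of the three numbers, and the gap from compound 2 up to compound 1 is also within the scatter. Across the three measured compounds no step beyond the scatter has been seen in this assay.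

Compound 4 `CSc1cccc(C(=O)N2CCCC(C(=O)Nc3ccc(Cl)cc3)C2)c1` differs from compound 2 by methylsulfanyl in place of 5-methyl-1,2,4-oxadiazol-3-yl on an aromatic carbon. Going by the values given here, no measured step touches this part of the structure. Among the compounds with values here, the only measured step, a number 9 percentage points lower from compound 1 to compound 3 (within the scatter), concerns a change elsewhere in the molecule and was within the scatter, so it gives no direction for the change at hand. With all three measured numbers low and no step beyond the scatter among them, the expectation for compound 4 is no movement beyond the scatter, an estimated step of a number 3 percentage points higher from compound 2 to compound 4 (within the scatter) in this assay. Compound 4 is therefore estimated at 3% in this assay, expected to lie between 0% and 15%.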

Compound 4, a percentage reported as inhibition, at one concentration (the size of the read-out at that concentration, not a potency): 0%
Compound 4: middle estimate off by 3 percentage points, on the high side; low and high end bracket the measured number.
By their numbers in this assay, from the lowest: compounds 2, 3, 4 and 1 (each within the scatter of the next).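

Going by these compounds alone, this is the first reading at this position, the aromatic carbon meta to a large group; the only earlier step concerned a change elsewhere in the molecule. Replacing 5-methyl-1,2,4-oxadiazol-3-yl, with 6 heavy atoms and one five-membered aromatic ring, by methylsulfanyl, with 2 heavy atoms and no ring, gives no change at the digits printed from compound 2 to compound 4 (within the scatter) in this assay, so for this pair neither the ring nor the larger group is needed for the number to stay low. No measured evidence bears on why the number stays put.

The compounds shown leave open whether this flat reading holds for groups of a different kind at this position, such as an amine or a carboxylic acid, since both groups here carry no net charge and no hydrogen-bond donor. They also leave open whether methylsulfanyl behaves the same way with the other amide partners in the series, such as those of compound 1 and compound 3, whose acyl side carries two trifluoromethyl groups rather than this substituent.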